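Thiophen-2-yl to ethynyl in the series

A few compounds are considered here, and "the series" means these few. Any claim that something is new, unique, unknown or untested is made for them only; others in the source may bear on it.

Measured so far in a functional assay on CEM-DNR-bulk cells (Homo sapiens), read by MTT assay, with a stated time of 72 h (a higher number here means a weaker inhibitor, a lower number a stronger inhibitor), as the read-out
compound 1 `COc1ncnc2c1c(-c1cc3ccccc3o1)cn2[C@@H]1O[C@H](CO)[C@@H](O)[C@H]1O` gives 10800 nM
compound 2 `CSc1ncnc2c1c(-c1cccs1)cn2[C@@H]1O[C@H](CO)[C@@H](O)[C@H]1O` gives > 20000 nM

For compound 2 the reading > 20000 nM is a limit only and not a number. Compound 3 (`C#Cc1cn([C@@H]2O[C@H](CO)[C@@H](O)[C@H]2O)c2ncnc(SC)c12`) carries ethynyl in place of thiophen-2-yl on an aromatic carbon and is otherwise the same as compound 2. Going by the values given here, no measured pair isolates this change, so the expectation is tentative. In this assay the estimated at least 5.0-fold lower number from compound 2 to compound 3 (0.69 log units; beyond the scatter) is expected to point towards a stronger inhibitor, beyond the scatter. For compound 3 the expected value is 4000 nM with an estimated range from 400 nM to 20000 nM here.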

Compound 3, half-maximal inhibitory concentration: 110 nM
Compound 3: the middle estimate sits 36-fold (1.56 log units) above what was measured; the measured number lies below the stated range.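

In this assay, ethynyl in place of thiophen-2-yl on this aromatic carbon, two ring bonds from the ring nitrogen, gives an at least 180-fold lower number from compound 2 to compound 3 (2.25 log units; beyond the scatter). Going by these compounds alone, this is the first one-place change read, and it shows that the group at this carbon alone can move the read-out strongly. The step has no upper bound, since compound 2 reads only as a limit: the limit of > 20000 nM in this assay, at which 1 of the 3 values shown sits.

From the compounds shown here alone, whether the shift follows from the triple bond itself or from the loss of the ring stays open. A nitrile, a propyl chain or an aminomethyl group at this carbon would help to separate the two.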